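The source may hold more compounds than are shown below. What is called first, only, known or untested is meant among the compounds shown, and "the series" means these compounds.

Values in a functional assay on MDA-MB-231 cells (Homo sapiens) for inhibition, read by MTT assay, with a stated time of 72 h; a lower number here means a stronger inhibitor, a higher number a weaker inhibitor:
- Compound 1 `Nc1ncnc2c1c(-c1cnc3[nH]ccc3c1)nn2CCCCCCCCC(=O)NO`: 11000 nM
- Compound 2 `Nc1nc2cc(-c3nn(CCC(=O)NO)c4ncnc(N)c34)ccc2o1`: > 50000 nM (a limit of the assay, not a number)
- Compound 3 `Nc1nc2cc(-c3nn(CCCCC(=O)NO)c4ncnc(N)c34)ccc2o1`: 21200 nM

In this assay, compound 3 gives 21200 nM, and compound 1 lies within the scatter of that value at 11000 nM. Compound 2 offers no number for comparison, only its limit.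

The next compound, compound 4 `Nc1nc2cc(-c3nn(CCCCCCCCC(=O)NO)c4ncnc(N)c34)ccc2o1`, keeps the core of compound 3 and lengthens its chain: 4-(hydroxycarbamoyl)butyl in place of hydroxycarbamoyl on a saturated chain carbon, four bonds along the chain from an aromatic nitrogen. In words, 4-(hydroxycarbamoyl)butyl stands in place of hydroxycarbamoyl on a saturated chain carbon, four bonds along the chain from an aromatic nitrogen.

Within the data shown here, one measured step bears directly on this change. Placing 2-(hydroxycarbamoyl)ethyl in place of hydroxycarbamoyl gave an at least 2.3-fold lower number from compound 2 to compound 3 (0.37 log units; beyond the scatter). As far as these compounds go, its true size stays open, since it starts from a limit. The same direction is therefore expected to continue, though this rests on a single step. The chain that compound 4 would gain is also carried, on a different core, by compound 1, which gives 11000 nM, so a very large gain is not assumed.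

The expected change is a 3.0-fold lower number from compound 3 to compound 4 (0.48 log units; beyond the scatter). For compound 4 the estimate is 7000 nM, with an expected range of 2000 nM to 22000 nM.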

Compound 4, half-maximal inhibitory concentration: 30300 nM
Estimate against measurement, compound 4: 4.3-fold (0.64 log units) below; measured number above the stated range.
By their numbers in this assay, from the lowest: compounds 1, 3 and 4 (each within the scatter of the next, the first and the last beyond it). At a limit, above all of these: compound 2.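

In this assay, lengthening the chain on the shared core, with 4-(hydroxycarbamoyl)butyl in place of hydroxycarbamoyl, leaves compounds 3 and 4 indistinguishable (a 1.4-fold higher number from compound 3 to compound 4 (0.16 log units; within the scatter)), so the fall in the number seen at the short end of the series (an at least 2.3-fold lower number from compound 2 to compound 3 (0.37 log units; beyond the scatter)) does not continue at this position. Compound 2 stands at a limit of the assay and not at a number, and its step to the long chain gives only a floor that lies within the scatter (an at least 1.6-fold lower number from compound 2 to compound 4 (0.21 log units; that floor lies within the scatter)), so it cannot show how far the long chain differs from the short one. With the chain held the same, the group on the aromatic carbon does separate the two compounds, though modestly (a 2.8-fold higher number from compound 1 to compound 4 (0.44 log units; beyond the scatter)), which shows that this long chain does not set the number by itself.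

The compounds shown leave open whether a chain of intermediate length or a still longer chain would read differently on this core. They also leave open how the number would respond to a carboxylic acid or an amine at the end of the chain in place of the hydroxycarbamoyl group.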